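Adding a methylpiperazine to the phenyl-bearing amidine

The compounds below may be only part of what the source reports. "The series", "measured", "known", "first", "only" and "open" are said of these compounds alone.

Two compounds have been measured in a functional assay on PC-3 cells (Homo sapiens) for cytotoxicity, read by MTT assay, with a stated time of 72 h; on this read-out higher numbers stand for weaker inhibition and lower numbers for stronger inhibition:
Compound 1, `CN1CCN(c2ccc(NC(=N)c3cc4cn[nH]c4cn3)cc2)CC1`, gives 45400 nM.
Compound 2, `N=C(Nc1ccccc1)c1cc2c(-c3ccccc3)n[nH]c2cn1`, gives 23000 nM.

Compound 2 has the lower of these two numbers, but its nearest neighbour, compound 1, sits within the scatter of repeated measurements, so the two cannot be told apart on this evidence. Among the measured compounds shown here, compound 1 and compound 2 differ in more than one place, so no single structural step connects them.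

Compound 3, `CN1CCN(c2ccc(NC(=N)c3cc4c(-c5ccccc5)n[nH]c4cn3)cc2)CC1`, has not yet been measured. It is built from compound 2 by one change: 4-methylpiperazin-1-yl in place of hydrogen on an aromatic carbon. Compound 1 carries the same 4-methylpiperazin-1-yl group and gives 45400 nM, while compound 2 gives 23000 nM; the two values are close, which gives no sign of a large shift tied to that group. The step from compound 2 to compound 3 is therefore expected to stay within the scatter, with no clear direction. The expected step is a 1.2-fold lower number from compound 2 to compound 3 (0.06 log units; within the scatter). For compound 3 the estimate is 20000 nM, with a range from 5000 nM to 60000 nM.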

Compound 3, half-maximal inhibitory concentration: 17100 nM
Beside the measured number, compound 3's estimate is 1.2-fold (0.07 log units) above it; the measured number falls inside the stated range.
By their numbers in this assay, from the lowest: compounds 3, 2 and 1 (each within the scatter of the next, the first and the last beyond it).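

In this assay, putting 4-methylpiperazin-1-yl on an aromatic carbon of the six-membered aromatic ring of carbon only, para to a large group, gives a 1.3-fold lower number from compound 2 to compound 3 (0.13 log units; within the scatter), so compound 2 and compound 3 cannot be told apart and the read-out at this position shows no clear response to this group. Among the compounds shown here, compound 3 also gives the first comparison that differs in only one place for the phenyl group: with 4-methylpiperazin-1-yl present in both compounds, phenyl in place of hydrogen on an aromatic carbon gives a 2.7-fold lower number from compound 1 to compound 3 (0.42 log units; beyond the scatter), a modest step and the only one here that clears the scatter. No measurement is available that would explain either step.

The compounds shown leave open whether a smaller amine such as dimethylamino, or a carboxylic acid, at the same position would remain within the scatter of compound 2 or move beyond it. They also leave open whether the phenyl step would hold without the 4-methylpiperazin-1-yl group, and whether a methyl group in place of the phenyl would give a step of similar size.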